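A few compounds are considered here, and "the series" means these few. Any claim that something is new, unique, unknown or untested is made for them only; others in the source may bear on it.

Measured so far:
- compound 1, `COc1cccc(C2=CC(c3ccc(Cl)cc3)NC(=S)N2)c1`: 150 nM
- compound 2, `COc1cccc(C2=CC(c3ccc(Br)cc3)NC(=S)N2)c1`: 135 nM
- compound 3, `COc1ccc(C(=O)C2OC2c2ccc(Cl)cc2)cc1`: 26 nM

In a functional assay on MCF7 cells (Homo sapiens) for antiproliferative activity, read by sulforhodamine B assay, with a stated time of 48 h (on this read-out lower numbers stand for stronger inhibition and higher numbers for weaker inhibition), compound 1 gives 150 nM and compound 2 gives 135 nM. The two share one core and differ only in bromo in place of chloro on an aromatic carbon; the result is a 1.1-fold lower number from compound 1 to compound 2 (0.05 log units; within the scatter), so the two numbers cannot be told apart with confidence.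

Compound 3 is built on a different core. Compound 3 gives 26 nM in this assay, the lowest of the three numbers; the difference between the two cores is not broken down here.

Compound 4, `COc1ccc(C(=O)C2OC2c2ccc(Br)cc2)cc1`, has not yet been measured in this assay. It differs from compound 3 in bromo in place of chloro on an aromatic carbon, and the surroundings of the change are described in the same words as for the pair of compound 1 and compound 2, so this is the same change made a second time, now on the core of compound 3. Since that change gave a 1.1-fold lower number from compound 1 to compound 2 (0.05 log units; within the scatter), compound 4 is expected to stay close to compound 3, with an estimated step of a 1.0-fold lower number from compound 3 to compound 4 (0.02 log units; within the scatter). The estimate for compound 4 in this assay is therefore 25 nM, expected to lie between 10 nM and 60 nM.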

Compound 4, half-maximal inhibitory concentration: 13 nM
Estimate against measurement, compound 4: 1.9-fold (0.28 log units) above; measured number inside the range.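

In this assay, putting bromo in place of chloro on the core of compound 3 gives a 2.0-fold lower number from compound 3 to compound 4 (0.30 log units; within the scatter), so compound 3 and compound 4 cannot be told apart with confidence. Set beside the earlier case, the same swap on the core of compound 1 gives a result that cannot be separated from this one, so within these four compounds it carries over from one core to the other without a visible difference: the same change on two cores in this assay, a 1.1-fold lower number (0.05 log units; within the scatter) from compound 1 to compound 2 and a 2.0-fold lower number (0.30 log units; within the scatter) from compound 3 to compound 4, 1.8-fold (0.26 log units) apart, within the scatter of two such steps. Going by these compounds alone, this shows only that on both cores the swap stays within the usual scatter of repeated measurements; it does not show a real gain from bromo on either core, it rests on just two pairs of compounds, and it says nothing about why the two groups give such similar numbers.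

The compounds shown leave open how a group of another kind, such as an amine or a carboxylic acid, would fare in place of chloro or bromo on that aromatic carbon, para to a large group. They also leave open whether the swap between chloro and bromo would stay this quiet on a third core.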